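A Methoxy Added to a Compound Already at the Limit

The source may report more compounds than this note shows. Statements on the series, on what has been measured and on what is new or still open speak of the compounds shown alone.

Compound 1 `COc1cc(Nc2nc3ccccc3nc2S(=O)(=O)c2ccccc2)cc(OC)c1` was tested in a functional assay on HCT-116 cells (Homo sapiens) for cytotoxicity, read by MTT assay, with a stated time of 72 h (a lower number here means a stronger inhibitor, a higher number a weaker inhibitor), where compound 1 gives 950 nM. Compound 3 `Cc1ccc(S(=O)(=O)c2nc3ccccc3nc2Nc2ccccc2)cc1` differs from compound 1 in more than one place, and in this assay compound 3 gives 1070 nM; the two values sit within the usual scatter of each other. Compound 2 `COc1cc(Nc2nc3ccccc3nc2S(=O)(=O)c2ccccc2)cc(OC)c1OC` carries one more methoxy than compound 1. In this assay compound 2 reaches only the limit of the assay, > 50000 nM, so no exact number is known for it. The change from compound 1 to compound 2 is the only single-point step among these three compounds, and it is large: an at least 52-fold higher number from compound 1 to compound 2 (1.72 log units; beyond the scatter). Compound 2 therefore stands at the limit of > 50000 nM in this assay, at which 1 of the 3 values shown sits, the weakest position the assay can report.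

Compound 4 `COc1ccc(S(=O)(=O)c2nc3ccccc3nc2Nc2cc(OC)c(OC)c(OC)c2)cc1` differs from compound 2 in one place: methoxy in place of hydrogen on an aromatic carbon. Among the compounds with values here, no measured step touches this ring, so the only guidance is that compound 2 starts at the limit. Compound 4 is therefore expected to stay at or near that limit, with an estimated 60000 nM and a range from 10000 nM to 300000 nM. The expected step that the limit leaves unreadable from compound 2 to compound 4 is thus no change beyond the scatter.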

Compound 4, half-maximal inhibitory concentration: > 50000 nM
Compound 4 ended at the assay's limit (the forecaster's own chance of this, stated with the estimate: 65%); the middle value does not contradict the limit.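

Compound 2 and compound 4 both reach only the limit of this assay, so the change from phenylsulfonyl to (4-methoxyphenyl)sulfonyl between them cannot be read as a step: the limit of > 50000 nM in this assay, at which 2 of the 4 values shown sit.

The compounds shown leave open how that same change would read on a compound clear of the limit, such as compound 1.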